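Sulfamoyl in Place of Chloro, Tested on Paw Edema

The source may hold more compounds than are shown below. What is called first, only, known or untested is meant among the compounds shown, and "the series" means these compounds.

Compound 1, `Cc1ccc(-c2nn(-c3ccc(Cl)cc3)cc2/C=N\c2ccccc2)cc1`: 49.3%
Compound 2, `Cc1ccc(-c2nn(-c3ccc(S(N)(=O)=O)cc3)cc2/C=N\c2ccccc2)cc1`: 57.1%
Compound 3, `Cc1ccc(-c2nn(-c3ccc(Cl)cc3)cc2C(CC(=O)c2ccc(Cl)cc2)C(=O)c2ccc(F)cc2)cc1`: 19.4%

Of the compounds shown here, three have been measured in a functional assay on the whole organism (strain Wistar albino) for inhibition, with Rattus norvegicus as the target, read by paw edema, with stated times of 1 h and 3 h, at a dose of 0.32 mmol/kg by the intraperitoneal route; a higher number here means more inhibition at the dose given (going by the name of the read-out), a lower number less inhibition. Compound 1 and compound 2 share one core and differ only in sulfamoyl in place of chloro on an aromatic carbon; this change gave a number 7.8 percentage points higher from compound 1 to compound 2 (within the scatter). Compound 3 has a different core; how the two cores differ is not broken down here, but in this assay compound 3 gives 19.4%, the lowest of the three.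

Compound 4, `Cc1ccc(-c2nn(-c3ccc(S(N)(=O)=O)cc3)cc2C(CC(=O)c2ccc(Cl)cc2)C(=O)c2ccc(F)cc2)cc1`, is not yet measured. It stands to compound 3 as compound 2 stands to compound 1: sulfamoyl in place of chloro on an aromatic carbon, the same change at the same place. Because a number 7.8 percentage points higher from compound 1 to compound 2 (within the scatter) lay within the scatter, the step of a number 5.6 percentage points higher from compound 3 to compound 4 (within the scatter) is also expected to stay small. In this assay compound 4 is expected to give about 25%, between 12% and 40%.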

Compound 4, a percentage reported as inhibition, in the whole organism at one dose (the size of the read-out at that dose, not a potency): 56.2%
Compound 4: the middle estimate sits 31.2 percentage points below what was measured; the whole stated range lies below it.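

In this assay the change from 4-chlorophenyl to 4-sulfamoylphenyl gave a number 36.8 percentage points higher from compound 3 to compound 4 (beyond the scatter) and so did not carry over with the same size from one core to the other: the same change on two cores in this assay, a number 7.8 percentage points higher (within the scatter) from compound 1 to compound 2 and a number 36.8 percentage points higher (beyond the scatter) from compound 3 to compound 4, 29 percentage points apart, beyond the scatter of two such steps. This shows that the size of the step cannot simply be taken from one core to the other in this series, and on the core of compound 1 the step does not stand clear of the scatter. It does not show which part of the two cores goes with the larger step, and two cores say nothing about how the change would run on a third.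

The compounds shown leave open whether another group in the place of chloro, such as a carboxylic acid or an amine, would give a step like that of sulfamoyl on either core.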